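Fluoro to trifluoromethyl: working notes on a small series

The compounds below may be only part of what the source reports. "The series", "measured", "known", "first", "only" and "open" are said of these compounds alone.

Among the compounds with values here, in a functional assay on SiHa cells (Homo sapiens) for inhibition, read by sulforhodamine B assay (on this read-out higher numbers stand for weaker inhibition of growth and lower numbers for stronger inhibition of growth), compound 1 `c1ccc(-c2ccc(-c3ccc(-c4nc5ccccc5[nH]4)cc3)cc2)cc1` gives 100000 nM, the highest number of the three measured so far. Compound 2 `Cc1ccc2[nH]c(-c3ccc(-c4ccc(-c5ccc(N(C)C)cc5)cc4)cc3)nc2c1` gives 7110 nM, the lowest number. Compound 3 `Fc1ccc(-c2ccc(-c3ccc(-c4nc5ccccc5[nH]4)cc3)cc2)cc1` gives 29700 nM, second highest of the three and so between the other two.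

The next structure is compound 4 `FC(F)(F)c1ccc(-c2ccc(-c3ccc(-c4nc5ccccc5[nH]4)cc3)cc2)cc1`, with trifluoromethyl in place of the fluoro of compound 3 on an aromatic carbon, para to a large group: trifluoromethyl in place of fluoro on an aromatic carbon.

Within the data shown here, only one measured step bears on this change: a 3.4-fold lower number from compound 1 to compound 3 (0.53 log units; beyond the scatter), a modest move with fluoro in place of hydrogen on an aromatic carbon. Among the measured compounds shown here, compound 2 differs from the others in more than one place and offers no comparable step. For the measured compounds named here, no measured step starts from fluoro, so the guidance is indirect. Going by the values given here, with a 3.4-fold lower number from compound 1 to compound 3 (0.53 log units; beyond the scatter) as the only guide, a small move toward a lower number in this assay is expected, probably within the scatter. The expected step is a 1.5-fold lower number from compound 3 to compound 4 (0.17 log units; within the scatter). Compound 4 is estimated at 20000 nM, with an expected range of 7000 nM to 60000 nM.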

Compound 4, concentration for 50% growth inhibition: 100000 nM
Beside the measured number, compound 4's estimate is 5.0-fold (0.70 log units) below it; measured number above the stated range.
By their numbers in this assay, from the lowest: compound 2; then compound 3; then compounds 1 and 4 (each within the scatter of the next).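

In this assay, trifluoromethyl in place of fluoro on this aromatic carbon, para to a large group, gives a 3.4-fold higher number from compound 3 to compound 4 (0.53 log units; beyond the scatter), so the direction of the earlier fluoro step does not extend to the larger fluorinated group. Set against hydrogen, trifluoromethyl gives no change at the digits printed from compound 1 to compound 4 (within the scatter), whereas fluoro gave a 3.4-fold lower number from compound 1 to compound 3 (0.53 log units; beyond the scatter); at this position, the fluoro step is therefore not shared by trifluoromethyl. Nothing measured here accounts for this difference between the two groups.

Still open, going by these compounds, is whether another group at this position, such as chloro, a nitrile or an amine, follows fluoro or trifluoromethyl. Also open, on these data alone, is what the dimethylamino group alone does here, as compound 2 differs from the others in more than one place.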